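Step from compound 2 to compound 3

The compounds below may be only part of what the source reports. "The series", "measured", "known", "first", "only" and "open" are said of these compounds alone.

- compound 1 `Cc1ccc(C2=NN(c3ccc(S(C)(=O)=O)cc3)C(=O)CC2)cc1` gives 220 nM
- compound 2 `Cc1cc(O)ccc1C1=NN(c2ccc(S(C)(=O)=O)cc2)C(=O)CC1` gives 2530 nM

In a functional assay on NCI-H522 cells (Homo sapiens) for inhibition, read by sulforhodamine B assay, with a stated time of 48 h (a lower number here means a stronger inhibitor of growth, a higher number a weaker inhibitor of growth), compound 2 has the higher of the two numbers, which makes it the weaker growth inhibitor of the pair. The unmeasured compound 3 `CCc1ccc(C2=NN(c3ccc(S(C)(=O)=O)cc3)C(=O)CC2)cc1` differs from compound 2 as follows: 4-ethylphenyl in place of 4-hydroxy-2-methylphenyl on a carbon with a double bond to nitrogen with 4-ethylphenyl in place of 4-hydroxy-2-methylphenyl on a carbon with a double bond to nitrogen.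

For the measured compounds named here, one measured step bears on this change: a 12-fold higher number from compound 1 to compound 2 (1.06 log units; beyond the scatter) which is large and came with 4-hydroxy-2-methylphenyl in place of 4-methylphenyl. Compound 3 gives up that same 4-hydroxy-2-methylphenyl. Going by the values given here, no measured step compares 4-ethylphenyl with 4-methylphenyl, so the reference is only approximate, and the range is kept wide. Compound 1 (220 nM) is the closest measured structure. A large step to a lower number is therefore expected in this assay and is put slightly short of the measured one in size. The estimated move is an 8.4-fold lower number from compound 2 to compound 3 (0.93 log units; beyond the scatter) and remains an expectation. For compound 3 the estimated value is 300 nM (expected range 100 nM to 900 nM).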

Compound 3, concentration for 50% growth inhibition: 330 nM
Compound 3: the middle estimate sits 1.1-fold (0.04 log units) below what was measured; the range from low to high includes it.
By their numbers in this assay, from the lowest: compounds 1 and 3 (each within the scatter of the next); then compound 2.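

Compound 3 shows that the loss seen with 4-hydroxy-2-methylphenyl on the carbon with a double bond to nitrogen is not fixed to the shared core: in this assay, 4-ethylphenyl in its place gives a 7.7-fold lower number from compound 2 to compound 3 (0.88 log units; beyond the scatter). The other new comparison, methyl in place of hydrogen on the saturated chain carbon bound to an aromatic carbon, gives a 1.5-fold higher number from compound 1 to compound 3 (0.18 log units; within the scatter), so 4-ethylphenyl and 4-methylphenyl cannot be told apart at this position in this assay, and a chain extended by that one carbon is accepted there, which the earlier pair could not show. Nothing measured alongside these growth-inhibition numbers offers an account of either step.

Since 4-hydroxy-2-methylphenyl differs from both 4-methylphenyl and 4-ethylphenyl in carrying a hydroxyl and a second ring substituent at once, the compounds shown do not separate what each of the two contributes to the weaker growth inhibition of compound 2. From the compounds shown here alone, how far the tolerance at this position extends also remains open, for example to 4-propylphenyl with its longer chain, or to a phenyl ring carrying a methoxy group or an amine in the same place.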